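The source may report more compounds than this note shows. Statements on the series, on what has been measured and on what is new or still open speak of the compounds shown alone.

In an assay on HEK293 cells for negative allosteric modulation of metabotropic glutamate receptor 5 (Homo sapiens), read by FLIPR, with a stated time of 1 h (a higher number here means a weaker inhibitor, a lower number a stronger inhibitor), the three measured compounds differ only in what sits on the amine nitrogen of the six-membered ring within the shared core. Compound 1 `CN1CCc2nc(C#Cc3ccccc3)sc2C1` carries a methyl there; in this assay compound 1 reaches only the limit of > 10000 nM, not a number. Compound 2 `CCN1CCc2nc(C#Cc3ccccc3)sc2C1` carries an ethyl instead, and in this assay compound 2 gives 1200 nM, so the step of an at least 8.3-fold lower number from compound 1 to compound 2 (0.92 log units; beyond the scatter) favours the ethyl. Compound 3 `O=C(C1CCOCC1)N1CCc2nc(C#Cc3ccccc3)sc2C1` carries an (oxan-4-yl)carbonyl on that nitrogen. In this assay compound 3 again reaches only the limit of > 10000 nM. Compound 3 thus stands at the weak end of what was measured, sharing the limit at which two of the three values sit (the limit of > 10000 nM in this assay, at which 2 of the 3 values shown sit). The step of an at least 8.3-fold higher number from compound 2 to compound 3 (0.92 log units; beyond the scatter) goes against potency, while the step that the two limits leave unreadable from compound 1 to compound 3 cannot be sized because both of its ends are limits.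

Compound 4 `O=S(=O)(C1CC1)N1CCc2nc(C#Cc3ccccc3)sc2C1` differs from compound 3 by the change (cyclopropylsulfonyl in place of (oxan-4-yl)carbonyl on an amine nitrogen in a ring). For the measured compounds named here, no measured step compares two such caps on the ring nitrogen; the only step that bears on capping it is an at least 8.3-fold higher number from compound 2 to compound 3 (0.92 log units; beyond the scatter), which lost potency. The step that the limit leaves unreadable from compound 3 to compound 4 is therefore expected to stay within the scatter. Compound 4 is estimated at 12000 nM, in a range from 3000 nM to 40000 nM, most likely reported as a limit.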

Compound 4, half-maximal inhibitory concentration: 34 nM
Compound 4: middle estimate off by 350-fold (2.55 log units), on the high side; measured number below the stated range.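

Capping this amine nitrogen in a ring does not in itself cost potency, as compound 3 alone might have suggested, since exchanging one cap for another gives an at least 290-fold lower number from compound 3 to compound 4 (2.46 log units; beyond the scatter) in this assay. For the compounds shown here, the cyclopropylsulfonyl group also outperforms the small alkyl groups at this place, with a 35-fold lower number from compound 2 to compound 4 (1.55 log units; beyond the scatter) against the ethyl and an at least 290-fold lower number from compound 1 to compound 4 (2.46 log units; beyond the scatter) against the methyl, so the identity of the cap matters far more here than the earlier compounds could reveal. The values of compound 1 and compound 3 remain limits rather than numbers, so the steps from them give only a minimum size: the limit of > 10000 nM in this assay, at which 2 of the 4 values shown sit.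

The change from compound 3 to compound 4 swaps the carbonyl link for a sulfonyl link and the six-membered ring for a three-membered ring at once, so the compounds shown cannot say which of the two carries the gain; a cyclopropylcarbonyl or a methylsulfonyl group on the same nitrogen would separate them. From the compounds shown here alone, how a larger group on the sulfonyl, such as phenyl, would compare also remains open.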